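The compounds below may be only part of what the source reports. "The series", "measured", "known", "first", "only" and "open" are said of these compounds alone.

Working notes on the series. Compound 1 `CCC1(CC)CC(CC)(CC)c2cc(NC(=O)Nc3ccc(C(F)(F)F)cc3)ccc2O1` and compound 2 `CCC1(CC)CC(CC)(CC)c2cc(NC(=O)Nc3ccc([N+](=O)[O-])cc3)ccc2O1` share one core; compound 3 `CCC1(CC)CC(C)(C)c2cc(NC(=O)Nc3ccc(C(F)(F)F)cc3)ccc2O1` and compound 4 `CCC1(CC)CC(C)(C)c2cc(NC(=O)Nc3ccc([N+](=O)[O-])cc3)ccc2O1` share another, and the difference between the two cores is not broken down here. In a functional assay on A2780 cells (Homo sapiens) for inhibition, with a stated time of 72 h (on this read-out lower numbers stand for stronger inhibition and higher numbers for weaker inhibition), compound 1 gives 2000 nM and compound 2 gives 2090 nM. The change between them, (nitro in place of trifluoromethyl on an aromatic carbon), made a step of a 1.0-fold higher number from compound 1 to compound 2 (0.02 log units; within the scatter). In this assay compound 3 gives 2450 nM; this value and those of compound 1 and compound 2 all lie within the scatter of one another, so no order among the three is read. Compound 4 is not yet measured. It differs from compound 3 by nitro in place of trifluoromethyl on an aromatic carbon, the same change as that from compound 1 to compound 2, at a place described in the same words. Going by the values given here, the earlier step of a 1.0-fold higher number from compound 1 to compound 2 (0.02 log units; within the scatter) gives the only guide available. On that basis, for compound 4 the expected step is a 1.0-fold higher number from compound 3 to compound 4 (0.01 log units; within the scatter). The value of compound 4 in this assay is estimated at 2500 nM, with a range of 1200 nM to 5200 nM.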

Compound 4, half-maximal inhibitory concentration: 2170 nM
Estimate against measurement, compound 4: 1.2-fold (0.06 log units) above; the measured number falls inside the stated range.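

On the core of compound 3 in this assay, nitro in place of trifluoromethyl gives a 1.1-fold lower number from compound 3 to compound 4 (0.05 log units; within the scatter). Set beside the same change on the core of compound 1, the new step does not differ from the earlier one: the same change on two cores in this assay, a 1.0-fold higher number (0.02 log units; within the scatter) from compound 1 to compound 2 and a 1.1-fold lower number (0.05 log units; within the scatter) from compound 3 to compound 4, 1.2-fold (0.07 log units) apart, within the scatter of two such steps. This shows that, for this one pair of groups, the absence of a readable effect carries over between these two cores; it does not show that a change with a readable effect would carry over, as neither step has a size beyond the scatter, nor that the same flat result would hold on any further core.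

The compounds shown carry only trifluoromethyl and nitro at this place on the aromatic ring, so what an amine, a carboxylic acid or a plain hydrogen would do there stays open. Also open, as far as these compounds go, is whether either core would respond differently to a group of another kind, such as a methoxy group or a longer chain.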